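Thiophene for pyridine on a weak cytotoxic triaryl core

This account rests on a few compounds, and the source may have more. Where it says the series, first, only, none or still open, it means among the compounds named here.

Measured compounds:
- Compound 1 `Oc1cccc(-c2cc(-c3cccnc3)nc(-c3cccc(Cl)c3)c2)c1` — "not determined" (no result reported)
- Compound 2 `Oc1ccc(-c2cc(-c3ccccn3)nc(-c3ccccc3Cl)c2)cc1` — "not determined" (no result reported)
- Compound 3 `Oc1ccc(-c2cc(-c3ccc(Cl)cc3)nc(-c3cccnc3)c2)cc1` — 20700 nM

Among the compounds with values here, in a functional assay on HCT-15 cells (Homo sapiens) for cytotoxicity, read by CCK-8 assay and cell counting, with a stated time of 2 days (a lower number here means a stronger inhibitor, a higher number a weaker inhibitor), compound 3 gives 20700 nM, the only number reported in this set, since compound 1 and compound 2 carry no result. Compound 3 is therefore a weak inhibitor and the sole reference point. Compound 4 `Oc1ccc(-c2cc(-c3ccc(Cl)cc3)nc(-c3cccs3)c2)cc1` differs from it in one place: thiophen-2-yl in place of pyridin-3-yl on an aromatic carbon. Within the data shown here, no measured pair in this set shows what such an exchange does, so nothing here indicates a direction beyond the scatter. Compound 4 is accordingly expected to remain close to the weak potency of its parent, with the step of a 1.4-fold lower number from compound 3 to compound 4 (0.14 log units; within the scatter) estimated to lie inside the usual scatter. Compound 4 is estimated at 15000 nM, within a range of 5000 nM to 45000 nM.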

Compound 4, half-maximal inhibitory concentration: 6470 nM
Estimate against measurement, compound 4: 2.3-fold (0.37 log units) above; low and high end bracket the measured number.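

In this assay, within the data shown here, thiophen-2-yl in place of pyridin-3-yl gives a 3.2-fold lower number from compound 3 to compound 4 (0.51 log units; beyond the scatter), the first measured change in this set. The position next to the ring nitrogen therefore responds to the ring it carries, modestly, and the exchange costs no potency. Nothing available explains this gain.

The compounds shown do not separate the effect of the sulfur from that of the smaller ring. They also leave open how a plain phenyl, a furan-2-yl or a thiophene bearing an amine would behave at this position.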